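A Fluorine Added to the Weakest of Three Analogues

The compounds below may be only part of what the source reports. "The series", "measured", "known", "first", "only" and "open" are said of these compounds alone.

Three related compounds have been tested in a functional assay on HBL-100 cells (Homo sapiens) for inhibition, read by sulforhodamine B assay, with a stated time of 48 h; on this read-out lower numbers stand for stronger inhibition of growth and higher numbers for weaker inhibition of growth. Compound 1 `COC(=O)[C@@]1(C)CCC=C2[C@@H]1CC[C@@H](C)[C@]2(C)Cc1c[nH]c2c(Cl)cccc12` gives 19000 nM and compound 2 `COC(=O)[C@@]1(C)CCC=C2[C@@H]1CC[C@@H](C)[C@]2(C)Cc1c(C)[nH]c2ccc(OC)cc12` gives 16000 nM, two numbers that sit within the scatter of each other. Compound 3 `COC(=O)[C@@]1(C)CC[C@@H]2C3=C1CC[C@@H](C)[C@]3(C)C[C@@H]1c3ccccc3N[C@H]21` gives 78000 nM, the highest of the three numbers and thus the weakest inhibitor of growth; its gap to each of the other two lies beyond the scatter. Compound 4 `COC(=O)[C@@]1(C)CC[C@@H]2C3=C1CC[C@@H](C)[C@]3(C)C[C@@H]1c3cc(F)ccc3N[C@H]21` keeps the whole core of compound 3 and differs in a single place: fluoro in place of hydrogen on an aromatic carbon. Among the compounds with values here, no pair of the measured compounds differs in only one place, so there is no directly comparable step to lean on. An exchange as small as this one usually moves a read-out of this kind only a little, and the expected step is a 1.3-fold lower number from compound 3 to compound 4 (0.11 log units; within the scatter), within or at most just beyond the scatter. Compound 4 is therefore estimated at 60000 nM in this assay, with a range from 25000 nM to 150000 nM.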

Compound 4, concentration for 50% growth inhibition: 18000 nM
For compound 4 the middle estimate is 3.3-fold (0.52 log units) above the measured one; measured number outside the range, below it.
By their numbers in this assay, from the lowest: compounds 2, 4 and 1 (each within the scatter of the next); then compound 3.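

In this assay, fluoro in place of hydrogen on this aromatic carbon gives a 4.3-fold lower number from compound 3 to compound 4 (0.64 log units; beyond the scatter). Compound 3 on its own could not show whether this ring responds to substitution, but this step shows that a single fluorine atom at this position, meta to a fused ring and para to a fused ring, can move growth inhibition beyond the usual scatter. No supporting data are available to explain the shift.

A bromine atom, a methyl group or an amine on the same carbon would help show whether this step is particular to fluoro or would appear with other groups there. Fluoro on the other aromatic carbons of that ring would show whether this carbon is the only one where such a change matters.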